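Swapping the group on the sulfonyl sulfur

The source may report more compounds than this note shows. Statements on the series, on what has been measured and on what is new or still open speak of the compounds shown alone.

- Compound 1 `Cc1cc(C)cc(S(=O)(=O)c2c(C(N)=O)[nH]c3ccc(Cl)cc23)c1` gives 13000 nM 
- Compound 2 `Cc1cc(C)cc(S(=O)(=O)c2c(C(=O)NS(=O)(=O)C(F)(F)F)[nH]c3ccc(Cl)cc23)c1` gives 141000 nM 

In an ADME assay on MT4 cells (Homo sapiens) for cytotoxicity, read by MTT assay, with a stated time of 5 days (a lower number here means that less compound is tolerated, a higher number that more compound is tolerated), compound 2 holds the higher of the two numbers (141000 nM), well clear of compound 1 (13000 nM). Compound 3 `Cc1cc(C)cc(S(=O)(=O)c2c(C(=O)NS(=O)(=O)c3ccc(F)cc3F)[nH]c3ccc(Cl)cc23)c1` has not yet been measured. It keeps the shared core of compound 2, with 2,4-difluorophenyl in place of trifluoromethyl on a sulfonyl sulfur.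

Among the compounds with values here, only one measured step bears on this change. That step (an 11-fold higher number from compound 1 to compound 2 (1.04 log units; beyond the scatter)) was large and beyond the scatter, and it put the (trifluoromethyl)sulfonyl group onto the amide-type nitrogen. It says nothing direct about replacing the group on the sulfur, so it is a weak guide. Compound 2 already sits at the top of the known range, so a moderate move towards a lower number is expected (a 3.1-fold lower number from compound 2 to compound 3 (0.50 log units; beyond the scatter)), smaller than the measured step. The estimated value for compound 3 is 45000 nM (expected range 12000 nM to 150000 nM).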

Compound 3, half-maximal cytotoxic concentration: 121000 nM
The estimate for compound 3 lay 2.7-fold (0.43 log units) below the measured number; low and high end bracket the measured number.
By their numbers in this assay, from the lowest: compound 1; then compounds 3 and 2 (each within the scatter of the next).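

In this assay, trifluoromethyl on the sulfonyl sulfur can give way to 2,4-difluorophenyl, which brings in a six-membered aromatic ring, with no change beyond the scatter: a 1.2-fold lower number from compound 2 to compound 3 (0.07 log units; within the scatter). The earlier step involved only the (trifluoromethyl)sulfonyl group, whereas a 9.3-fold higher number from compound 1 to compound 3 (0.97 log units; beyond the scatter) shows that a second sulfonyl group with a different substituent on the amide-type nitrogen also stands well clear of the unsubstituted amide of compound 1. Nothing available here explains why these two sulfur substituents give readings so close together.

From the compounds shown here alone, two groups on the sulfur cannot show how general this is, so a short chain such as methyl or a group carrying an amine remains open. Also open, going by these compounds, is whether a carboxylic acid in place of the whole nitrogen-substituted amide would fall in the same range.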